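The compounds below may be only part of what the source reports. "The series", "measured", "known", "first", "only" and "open" are said of these compounds alone.

In a functional assay on K562 cells (Homo sapiens) for cytotoxicity, read by sulforhodamine B assay (on this read-out higher numbers stand for weaker inhibition of growth and lower numbers for stronger inhibition of growth), compound 1 (`CC1=CC[C@@H]([C@@](C)(O)CCCC(C)(C)NC=S)CC1`) gives 16700 nM and compound 2 (`CC1=CC[C@@H]([C@@](C)(O)CCCC(C)(C)NC(=S)N/N=C\c2ccc(N(C)C)cc2)CC1`) gives 80 nM as the lower of the two numbers, with the gap between them beyond the scatter. Compound 3 (`CC1=CC[C@@H]([C@@](C)(O)CCCC(C)(C)NC(=S)N/N=C\c2ccc(Cl)cc2)CC1`) has not yet been measured. The change from compound 2 is chloro in place of dimethylamino on an aromatic carbon with chloro in place of dimethylamino on an aromatic carbon, para to a large group. Within the data shown here, no measured pair isolates this position, so the size of the step remains a judgement. A modest rise in the number is expected in this assay and it may lie near the edge of the scatter. The expected step is a 2.5-fold higher number from compound 2 to compound 3 (0.40 log units; beyond the scatter) in the direction of weaker inhibition of growth. For compound 3 the estimate is 200 nM with an expected range from 50 nM to 800 nM on this read-out.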

Compound 3, concentration for 50% growth inhibition: 40 nM
For compound 3 the middle estimate is 5.0-fold (0.70 log units) above the measured one; measured number outside the range, below it.
By their numbers in this assay, from the lowest: compounds 3 and 2 (each within the scatter of the next); then compound 1.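

In this assay, chloro in place of dimethylamino on an aromatic carbon, para to a large group, gives a 2.0-fold lower number from compound 2 to compound 3 (0.30 log units; within the scatter), so this change cannot be told apart from the scatter on this read-out. Among these compounds, no earlier pair isolated this position; it now carries either group with no resolved difference in inhibition of growth, which compound 2 alone could not show. Nothing measured on either group is available to account for this result.

The compounds shown leave open whether a carboxylic acid, a primary amine or a plain hydrogen at this position would remain level with compound 2 and compound 3. As far as these compounds go, it is also open whether a methoxy or a bromo group would do the same, so the range of groups accepted here is still undefined.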